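The source may hold more compounds than are shown below. What is called first, only, known or untested is meant among the compounds shown, and "the series" means these compounds.

Measured in an assay on NIH3T3 cells for displacement of a labelled ligand from melatonin receptor type 1B (Homo sapiens), with a stated time of 90 min; on this read-out lower numbers stand for stronger inhibition and higher numbers for weaker inhibition:
compound 1, `COc1ccc(OC(C)CNC(C)=O)cc1`, gives 12600 nM
compound 2, `CC(=O)NCC(C)Oc1ccccc1`, gives 1150 nM
compound 3, `CC(=O)NCCOc1ccccc1`, gives 5500 nM

Compound 4, `COc1cccc(OCCNC(C)=O)c1`, has not yet been measured in this assay. The cores of compound 2 and compound 3 differ by hydrogen in place of methyl on a saturated chain carbon bound to an oxygen on an aromatic ring and a saturated chain carbon, and that change gave a 4.8-fold higher number from compound 2 to compound 3 (0.68 log units; beyond the scatter). The change from compound 2 to compound 1 is methoxy in place of hydrogen on an aromatic carbon, and it gave an 11-fold higher number from compound 2 to compound 1 (1.04 log units; beyond the scatter). Compound 4 arises from compound 3 through (methoxy in place of hydrogen on an aromatic carbon). In compound 1 the entering group sits para to a group of 8 heavy atoms, whereas in compound 4 it sits meta to a group of 7 heavy atoms, so this is the same kind of change, not the same one. The step for compound 4 is expected to be somewhat smaller than an 11-fold higher number from compound 2 to compound 1 (1.04 log units; beyond the scatter), as the place differs, giving an expected 2.7-fold higher number from compound 3 to compound 4 (0.44 log units; beyond the scatter). Compound 4 is therefore estimated at 15000 nM, likely between 4000 nM and 60000 nM.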

Compound 4, inhibition constant: 67.6 nM
The estimate for compound 4 lay 220-fold (2.35 log units) above the measured number; the measured number lies below the stated range.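

In this assay, methoxy in place of hydrogen on an aromatic carbon gave an 81-fold lower number from compound 3 to compound 4 (1.91 log units; beyond the scatter), so the change cannot simply be carried from one core to another in this series, in either size or direction: the same change on two cores in this assay, an 11-fold higher number (1.04 log units; beyond the scatter) from compound 2 to compound 1 and an 81-fold lower number (1.91 log units; beyond the scatter) from compound 3 to compound 4, 890-fold (2.95 log units) apart, beyond the scatter of two such steps

The two steps differ in two respects at once: in compound 4 the methoxy sits meta to a group of 7 heavy atoms, at a different place from that in compound 1, and the core of compound 1 carries a chain methyl absent from compound 4. These pairs therefore do not show which difference matters.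

The compounds shown leave open how methoxy behaves at the same place on both cores. They also leave open whether an ethoxy or hydroxy group at the place held by methoxy in compound 4 would give a comparable number.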